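This account rests on a few compounds, and the source may have more. Where it says the series, first, only, none or still open, it means among the compounds named here.

Compound 3 `Cc1cc(C)cc(NC(=O)Nc2ccc(Nc3ncnc4c3OCCN4)cc2)c1` stands second highest of the three numbers in an assay on isolated protein for inhibition of proto-oncogene tyrosine-protein kinase receptor Ret (Homo sapiens), read by 33P incorporation, with stated times of 15 min and 40 min (a higher number here means a weaker inhibitor, a lower number a stronger inhibitor), where compound 3 gives 1070 nM. Compound 1 `O=C(Nc1ccc(Br)cc1)Nc1ccc(Nc2ncnc3c2OCCN3)cc1` gives 2220 nM, and compound 2 `O=C(Nc1ccc(Nc2ncnc3c2OCCN3)cc1)Nc1ccc(C(F)(F)F)cc1` gives 306 nM. The move to compound 4 `O=C(Nc1ccc(Nc2ncnc3c2OCCN3)cc1)Nc1cccs1` is thiophen-2-yl in place of 3,5-dimethylphenyl on an amide-type nitrogen. Two measured steps swap the ring on that same nitrogen: a 2.1-fold lower number from compound 1 to compound 3 (0.32 log units; beyond the scatter) and a 3.5-fold higher number from compound 2 to compound 3 (0.54 log units; beyond the scatter). Both are modest, so a modest shift in this assay is expected here as well; the thiophen-2-yl carries none of the substituents seen on the rings of compound 1, compound 2 or compound 3, and a somewhat higher number is expected. Compound 4 is therefore estimated at 2500 nM, with a range from 800 nM to 8000 nM. This estimate means a 2.3-fold higher number from compound 3 to compound 4 (0.37 log units; beyond the scatter) is expected.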

Compound 4, half-maximal inhibitory concentration: > 10000 nM
Compound 4: only a limit was reported; the forecaster's own chance of this, stated with the estimate: 5%; middle value at least 4.0-fold (0.60 log units) from the limit.
By their numbers in this assay, from the lowest: compound 2; then compound 3; then compound 1. At a limit, above all of these: compound 4.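

Compound 4 gives no number in this assay, only a limit: the limit of > 10000 nM in this assay, at which 1 of the 4 values shown sits. The earlier swaps on this amide-type nitrogen were all modest, so the ring here can matter more than compounds 1 to 3 suggested: an at least 9.3-fold higher number from compound 3 to compound 4 (0.97 log units; beyond the scatter), an at least 4.5-fold higher number from compound 1 to compound 4 (0.65 log units; beyond the scatter) and an at least 32-fold higher number from compound 2 to compound 4 (1.51 log units; beyond the scatter). Among the four compounds, only the five-membered thiophen-2-yl, the one ring with sulfur and no substituent, reaches that limit.

Which of these differences counts remains open. A plain phenyl or a furan-2-yl on the same nitrogen could separate ring size, sulfur and substituents.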